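Trading a Methylsulfanyl for a Methylsulfonyl Group

A few compounds are considered here, and "the series" means these few. Any claim that something is new, unique, unknown or untested is made for them only; others in the source may bear on it.

Compound 1 `CSc1ccc(OCc2ccc(F)cc2)c(C2=C(c3cccc(C(=O)O)c3)CCC2)c1` was tested in an assay on isolated protein for inhibition of prostaglandin E2 receptor EP1 subtype (Homo sapiens) (a higher number here means a weaker inhibitor, a lower number a stronger inhibitor), and gives 31.6 nM. Its close relative compound 2 `CSc1ccc(OCc2ccc(F)cc2F)c(C2=C(c3cccc(C(=O)O)c3)CCC2)c1` gives 15.9 nM, and compound 3 `O=C(O)c1cncc(C2=C(c3cc(Cl)ccc3OCc3ccc(F)cc3F)CCC2)n1` gives 2 nM. Compound 1 thus has the highest of the three numbers: the step of a 2.0-fold lower number from compound 1 to compound 2 (0.30 log units; within the scatter) lies within the scatter, while compound 3 sits well lower. The unmeasured compound 4 `CS(=O)(=O)c1ccc(OCc2ccc(F)cc2)c(C2=C(c3cccc(C(=O)O)c3)CCC2)c1` differs from compound 1 in one place: methylsulfonyl in place of methylsulfanyl on an aromatic carbon. Among the compounds with values here, no measured step involves this change; the only single-point step, a 2.0-fold lower number from compound 1 to compound 2 (0.30 log units; within the scatter), concerns a different group at a different place and offers no guide. The estimate for compound 4 is therefore broad, centred on 60 nM with a range from 15 nM to 250 nM, which would be an expected 1.9-fold higher number from compound 1 to compound 4 (0.28 log units; within the scatter).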

Compound 4, half-maximal inhibitory concentration: 79.4 nM
Estimate against measurement, compound 4: 1.3-fold (0.12 log units) below, and the stated range covers the measured number.
By their numbers in this assay, from the lowest: compound 3; then compounds 2 and 1 (each within the scatter of the next); then compound 4.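

Moving from methylsulfanyl to methylsulfonyl at this position, para to the (4-fluorobenzyl)oxy group, gives a 2.5-fold higher number from compound 1 to compound 4 (0.40 log units; beyond the scatter) in this assay. This is the first change shown at this position, and it leaves compound 4 a weaker inhibitor than compound 1, though the step is modest. No measurement here explains this step.

Still open, on these data alone, is how a methoxy group or an amine at this position would compare. It is also unclear whether the same change would have a similar effect on compound 2.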